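Chloro on the Benzoyl Ring: Estimating Compound 3

The compounds below may be only part of what the source reports. "The series", "measured", "known", "first", "only" and "open" are said of these compounds alone.

compound 1, `CCOC(=O)Cc1n[nH]c(N)n1`: 33.6%
compound 2, `CCOC(=O)Cc1nc(N)n(C(=O)c2ccccc2)n1`: 38.5%

Of the compounds shown here, two have been measured in a functional assay on the whole organism (strain albino) for inhibition, with Rattus norvegicus as the target, read by paw edema, with stated times of 30 min and 2 h, at a dose of 5 mg/kg by the oral route; a higher number here means more inhibition at the dose given (going by the name of the read-out), a lower number less inhibition. In this assay compound 1 gives 33.6%. In this assay compound 2 gives 38.5%. Compound 2 holds the higher of the two numbers, but its gap to compound 1 falls within the scatter of repeated measurements, so the two values cannot be put in order.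

Compound 3, `CCOC(=O)Cc1nc(N)n(C(=O)c2ccc(Cl)cc2)n1`, has not yet been measured. It differs from compound 2 by chloro in place of hydrogen on an aromatic carbon. For the measured compounds named here, no measured pair shows this change, so the expectation rests on compound 2 alone. In this assay compound 3 is expected to give 42%, with a range from 28% to 56%. The step expected in this assay is a number 3.5 percentage points higher from compound 2 to compound 3 (within the scatter), a small rise that stays within the scatter.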

Compound 3, a percentage reported as inhibition, in the whole organism at one dose (the size of the read-out at that dose, not a potency): 42.3%
Beside the measured number, compound 3's estimate is 0.3 percentage points below it, within the range that was stated.
By their numbers in this assay, from the lowest: compounds 1, 2 and 3 (each within the scatter of the next).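

In this assay, the change from phenyl to 4-chlorophenyl gives a number 3.8 percentage points higher from compound 2 to compound 3 (within the scatter), so compound 2 and compound 3 cannot be put in order. This first pair for the change shows that a chloro on the aromatic carbon para to a large group leaves the read-out at this dose indistinguishable from that with hydrogen there, although it gives no sign of a real gain. No evidence is available that bears on this result.

The compounds shown leave open whether a different group at this place, such as a methoxy group, an amine or a carboxylic acid, would shift the inhibition beyond the scatter. They also leave open how compound 2 and compound 3 would compare at other doses, since a reading at one dose is not a potency.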